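The source may hold more compounds than are shown below. What is called first, only, known or untested is meant among the compounds shown, and "the series" means these compounds.

In a functional assay on MCF7 cells (Homo sapiens) for antiproliferative activity, read by MTT assay, with a stated time of 48 h (a higher number here means a weaker inhibitor, a lower number a stronger inhibitor), compound 1 (`O=C(/C=C/c1ccc(Br)cc1)Nc1cc(-c2ccc(Br)cc2)[nH]n1`) gives 920 nM and compound 2 (`O=C(/C=C/c1ccc([N+](=O)[O-])cc1)Nc1cc(-c2ccccc2)[nH]n1`) gives 630 nM so far. These two values lie within the scatter of each other, so compound 2 cannot be separated from compound 1 on the present numbers. The next compound, compound 3 (`O=C(/C=C/c1ccc(Br)cc1)Nc1cc(-c2ccccc2)[nH]n1`), has no number yet. Its change from compound 2 is bromo in place of nitro on an aromatic carbon of a six-membered aromatic ring of carbon only, para to a large group (bromo in place of nitro on an aromatic carbon). For the measured compounds named here, no measured pair shows this exchange alone, so the data give no direct size for it. Going by the values given here, the nearest guide is compound 1 at 920 nM as the only measured compound with bromo at that place, and its value is within the scatter of compound 2 at 630 nM in the same readout. A small expected step towards a higher number, not beyond the scatter, is the working assumption (a 1.3-fold higher number from compound 2 to compound 3 (0.10 log units; within the scatter)). Compound 3 is estimated at 800 nM within an expected range (300 nM to 2200 nM).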

Compound 3, half-maximal inhibitory concentration: 1240 nM
Estimate against measurement, compound 3: 1.6-fold (0.19 log units) below; the measured number falls inside the stated range.
By their numbers in this assay, from the lowest: compounds 2, 1 and 3 (each within the scatter of the next).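

In this assay, for the compounds shown here, the exchange of bromo for nitro on an aromatic carbon, para to a large group, can now be read alone for the first time: a 2.0-fold higher number from compound 2 to compound 3 (0.29 log units; within the scatter), so the two groups are not separated at this place despite their different heavy-atom and acceptor counts. The second single-place pair, hydrogen in place of bromo on an aromatic carbon at the other end of the molecule, gives a 1.3-fold higher number from compound 1 to compound 3 (0.13 log units; within the scatter), so neither of the two places examined has yet shown a step beyond the scatter. No supporting measurement bears on either step, and the numbers stand without an accompanying explanation.

Open, as far as these compounds go, is how an amine, a methoxy group or a carboxylic acid on the same aromatic carbon would read against nitro and bromo, and whether any group there gives a step beyond the scatter. From the compounds shown here alone, each step also rests on a single pair, so it remains open whether the same small steps would hold with a different group at the other place.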